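Ethylcarbamoyl in Place of Propylcarbonyl at a Melatonin Receptor

The source may report more compounds than this note shows. Statements on the series, on what has been measured and on what is new or still open speak of the compounds shown alone.

Compound 1, `CCCC(=O)NCCCc1cccc2c1C[C@@H](CCCCc1ccccc1)O2`, gives 30 nM in an assay on NIH3T3 cells for binding affinity to melatonin receptor type 1B (Homo sapiens); on this read-out higher numbers stand for weaker inhibition and lower numbers for stronger inhibition.
Compound 2, `CC(C)C(=O)NC[C@@H]1C[C@H]1c1cccc2c1C[C@@H](CCCCc1ccccc1)O2`, gives 90 nM in this assay.

Of the two measured compounds, compound 1 has the lower number, and compound 2 stands a step higher that lies beyond the usual scatter of repeated measurements. These two compounds differ from each other in more than one place, so no single step between them can be read off; only their two values are shown.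

Compound 3, `CCNC(=O)NCCCc1cccc2c1C[C@@H](CCCCc1ccccc1)O2`, has not yet been measured. It differs from compound 1 by ethylamino in place of propyl on a carbonyl carbon, so that the (propylcarbonyl)amino group becomes an (ethylcarbamoyl)amino group while the rest of the molecule stays the same. Among the measured compounds shown here, nothing among the measured compounds tells how this exchange moves the number in this assay. Since only one part of the molecule is altered, a small step is expected, if any, toward a weaker result, probably within or just beyond the scatter. Compound 3 is therefore estimated at 60 nM, with a range from 15 nM to 200 nM, which amounts to an expected step of a 2.0-fold higher number from compound 1 to compound 3 (0.30 log units; within the scatter).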

Compound 3, inhibition constant: 40 nM
For compound 3 the middle estimate is 1.5-fold (0.18 log units) above the measured one, and the stated range covers the measured number.
By their numbers in this assay, from the lowest: compounds 1 and 3 (each within the scatter of the next); then compound 2.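

In this assay, among the compounds shown here, ethylamino in place of propyl on a carbonyl carbon amounts to a 1.3-fold higher number from compound 1 to compound 3 (0.12 log units; within the scatter), the first step at this position that can be read directly. The exchange turns the (propylcarbonyl)amino group into an (ethylcarbamoyl)amino group: a carbon gives way to a nitrogen and a hydrogen-bond donor enters, yet on this read-out the two compounds cannot be told apart, so at this place on the core of compound 1 the change is tolerated without a step beyond the scatter. No measurement shown here bears on why the two groups read alike.

The compounds shown leave open how this carbonyl carbon responds to other groups, such as methylamino, dimethylamino, methoxy or a longer chain like butylamino, any of which might give a step beyond the scatter where ethylamino did not. On these data alone, it also remains open whether ethylamino would read the same on the carbonyl carbon of compound 2, which differs from compound 1 in more than one place.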